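The source may hold more compounds than are shown below. What is called first, only, known or untested is meant among the compounds shown, and "the series" means these compounds.

Compound 1, `CC1(C)CC(=O)c2cc(C#N)c(SCc3ccccc3)nc2C1`, gives 4800 nM in an in vitro functional assay on cells for antagonist activity at metabotropic glutamate receptor 1 (Rattus norvegicus), read by inositol phosphate accumulation; a higher number here means a weaker inhibitor, a lower number a stronger inhibitor.
Compound 2, `CCCCNc1nc2c(cc1C#N)C(=O)CC(C)(C)C2`, gives 1700 nM in this assay.
Compound 3, `CC1(C)CC(=O)c2cc(C#N)c(N3CC=C(c4ccccc4)CC3)nc2C1`, gives < 1000 nM in this assay, which is a limit of the assay and not a number.

The three measured compounds share one core and differ in a single substituent on it. For compound 1 and compound 2 a number is in hand; for compound 3 only a limit is known: the limit of < 1000 nM in this assay, at which 1 of the 3 values shown sits. Compound 3 can therefore not be ranked against the numbers of compound 1 and compound 2; it can only be said that its value sits at that limit.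

Compound 4, `CC1(C)CC(=O)c2cc(C#N)c(N3CC=C(c4ccc(F)cc4)CC3)nc2C1`, is not yet measured. It differs from compound 3 by fluoro in place of hydrogen on an aromatic carbon. Going by the values given here, no measured pair shows this change, so there is no step to lean on, and a change of this kind is expected to give no step beyond the scatter in this assay. Compound 4 is therefore estimated at 500 nM, within a range of 150 nM to 1500 nM. The step from compound 3 to compound 4 is expected to be a step that the limit leaves unreadable from compound 3 to compound 4.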

Compound 4, half-maximal inhibitory concentration: 110 nM
Estimate against measurement, compound 4: 4.5-fold (0.66 log units) above; measured number below the stated range.
By their numbers in this assay, from the lowest: compound 4; then compound 2; then compound 1.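

No new step can be read from compound 3 to compound 4 in this assay, because the value of compound 3 is a limit and not a number: the limit of < 1000 nM in this assay, at which 1 of the 4 values shown sits.

The compounds shown leave open how large the change from phenyl to 4-fluorophenyl is, and whether it goes beyond the usual scatter at all.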